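A few compounds are considered here, and "the series" means these few. Any claim that something is new, unique, unknown or untested is made for them only; others in the source may bear on it.

Notes on the series, step from compound 3 to compound 4.

Three compounds share one core and differ only in the aryl group carried by the ring nitrogen. Compound 1 `CCCc1nc(-c2ccccc2)c(CNCCN2CCN(c3cccc(C(F)(F)F)c3)CC2)o1` gives 56.3% in an assay on HEK293 cells for inhibition of Voltage-dependent T-type calcium channel subunit alpha-1G (Homo sapiens), read by fluorescence, tested at 10 uM; a lower number here means less inhibition, a higher number more inhibition at the concentration tested (going by the name of the read-out). Compound 2 `CCCc1nc(-c2ccccc2)c(CNCCN2CCN(c3cccc(C)c3)CC2)o1` gives 43.1%. Compound 3 `CCCc1nc(-c2ccccc2)c(CNCCN2CCN(c3ccccc3Cl)CC2)o1` gives 60.1%, the highest of the three numbers, although the gap to compound 1 lies within the scatter a number 3.8 percentage points higher from compound 1 to compound 3 (within the scatter) and only the gap to compound 2 is beyond it a number 17 percentage points higher from compound 2 to compound 3 (beyond the scatter). Compound 4 `CCCc1nc(-c2ccccc2)c(CNCCN2CCN(c3ccc(F)cc3)CC2)o1` is not yet measured.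

The change from compound 3 to compound 4 is 4-fluorophenyl in place of 2-chlorophenyl on an amine nitrogen in a ring. Both earlier aryl swaps on this nitrogen bear on it: one left the number unchanged within the scatter a number 3.8 percentage points higher from compound 1 to compound 3 (within the scatter), the other moved it by a modest amount a number 17 percentage points higher from compound 2 to compound 3 (beyond the scatter); the methyl for trifluoromethyl swap gave a number 13.2 percentage points lower from compound 1 to compound 2 (beyond the scatter). Among the compounds with values here, a 4-fluorophenyl has no precedent here, so a small step downward or none beyond the scatter is expected, a number 10.1 percentage points lower from compound 3 to compound 4 (beyond the scatter). Compound 4 is estimated at 50%, between 35% and 65%.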

Compound 4, a percentage reported as inhibition, at one concentration (the size of the read-out at that concentration, not a potency): 54.1%
For compound 4 the middle estimate is 4.1 percentage points below the measured one, within the range that was stated.
By their numbers in this assay, from the lowest: compound 2; then compounds 4, 1 and 3 (each within the scatter of the next).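

In this assay, the 4-fluorophenyl on the ring nitrogen cannot be told apart from the 2-chlorophenyl (a number 6 percentage points lower from compound 3 to compound 4 (within the scatter)) or from the 3-(trifluoromethyl)phenyl (a number 2.2 percentage points lower from compound 1 to compound 4 (within the scatter)), whereas it does separate from the 3-methylphenyl (a number 11 percentage points higher from compound 2 to compound 4 (beyond the scatter)). Across these four compounds, the three aryl groups carrying fluorine or chlorine therefore form one group within the scatter, with different substitution patterns in their names, and compound 2, the only one with neither halogen, stands apart; no compound shown goes against this. The data offer nothing that explains this grouping.

On these data alone, whether the separation of compound 2 follows the methyl group itself or its place on the ring stays open, and a 4-methylphenyl or a 2-methylphenyl would bear on that. An unsubstituted phenyl, a methoxy group or a nitrile on this ring also remains untested among the compounds shown.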